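The compounds below may be only part of what the source reports. "The series", "measured", "known", "first", "only" and "open" are said of these compounds alone.

For the measured compounds named here, compound 3 `Cc1ccc(Nc2nc(SCc3cn(CC(=O)NC(=O)Nc4ccccn4)nn3)nc(-c3ccc(C(C)C)cc3)c2C#N)cc1` is the only member of this set with a number in a functional assay on MGC-803 cells (Homo sapiens) for inhibition, read by MTT assay, with a stated time of 72 h; on this read-out lower numbers stand for stronger inhibition and higher numbers for weaker inhibition: compound 3 gives 3360 nM. Compound 1 `CC(C)c1ccc(-c2nc(SCc3cn(CC(=O)NC(=O)Nc4ccccn4)nn3)nc(Nc3ccccc3F)c2C#N)cc1` reaches only a limit in this assay, > 64000 nM. Compound 2 `COc1ccc(Nc2nc(SCc3cn(CC(=O)NC(=O)Nc4ccccn4)nn3)nc(-c3ccc(C(C)C)cc3)c2C#N)cc1` likewise stops at a limit, > 64000 nM. Because of the limit of > 64000 nM in this assay, at which 2 of the 3 values shown sit, the step that the two limits leave unreadable from compound 1 to compound 2 cannot be read. The steps of an at least 19-fold lower number from compound 1 to compound 3 (1.27 log units; beyond the scatter) and an at least 19-fold lower number from compound 2 to compound 3 (1.27 log units; beyond the scatter) are both large. Compound 4 `Cc1ccc(Nc2nc(SCc3cn(CC(=O)NC(=O)Nc4ccccn4)nn3)nc(-c3ccc(Br)cc3)c2C#N)cc1` differs from compound 3 in one place: bromo in place of isopropyl on an aromatic carbon. All three measured steps alter the group on the nitrogen on the aromatic ring, not this position, so none of them bears directly on the change. For compound 4 a step within the scatter is expected, a 1.5-fold higher number from compound 3 to compound 4 (0.17 log units; within the scatter), though with wide uncertainty. The estimate for compound 4 is 5000 nM, between 1500 nM and 30000 nM.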

Compound 4, half-maximal inhibitory concentration: 13900 nM
Compound 4: the middle estimate sits 2.8-fold (0.44 log units) below what was measured; low and high end bracket the measured number.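

The earlier compounds shown here all carry isopropyl on this aromatic carbon, so they could not show whether the position responds to change. In this assay, going from 4-isopropylphenyl to 4-bromophenyl gives a 4.1-fold higher number from compound 3 to compound 4 (0.62 log units; beyond the scatter), a shift beyond the scatter, though modest where the steps at the group on the nitrogen were large. Nothing shown gives a reason for this step. The compounds leave open how an amine, a carboxylic acid or a longer chain would read at this carbon, and whether bromo would give the same step with another group on the nitrogen.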